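The source may hold more compounds than are shown below. What is called first, only, known or untested is meant among the compounds shown, and "the series" means these compounds.

Measured compounds in a functional assay on the whole organism (strain CF-1) with Mus musculus as the target; on this read-out higher numbers stand for an effect only at larger amounts of compound and lower numbers for an effect already at smaller amounts:
- compound 1, `Cc1nnc(CN(C)C)n1-c1ccc(Cl)cc1C(=O)c1ccccc1`: 2.2 mg/kg
- compound 2, `Cc1nnc(CN2CCCC2)n1-c1ccc(Cl)cc1C(O)c1ccccc1`: 16 mg/kg; 5 mg/kg (2 entries)
- compound 3, `CN(C)Cc1nnc(-c2ccncc2)n1-c1ccc(Cl)cc1C(=O)c1ccccc1Cl`: 20 mg/kg

Compound 3 has the highest number of the two compounds that give a single value in this assay. Its nearest neighbour is compound 1, whose dose is lower by a margin that is beyond the usual scatter. Compound 2 has several entries, (the several entries of compound 2 in this assay, 16 mg/kg; 5 mg/kg (2 entries)), and so gives no single number to rank against; compound 1 and compound 3 differ from compound 2 in more than one place, and compound 1 and compound 3 also differ from each other in more than one place, so no single change can be read out of these values.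

Compound 4, `CN(C)Cc1nnc(C2CC2)n1-c1ccc(Cl)cc1C(=O)c1ccccc1Cl`, has not yet been measured. It is derived from compound 3 by the change (cyclopropyl in place of pyridin-4-yl on an aromatic carbon). Among the measured compounds shown here, no measured pair isolates this change, so there is no direct evidence of its size. With only compound 3 as anchor, the step expected in this assay is a 2.0-fold lower number from compound 3 to compound 4 (0.30 log units; within the scatter).

Compound 4 is therefore expected to give about 10 mg/kg in this assay, with a likely range from 3 mg/kg to 30 mg/kg.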

Compound 4, dose for half-maximal effect: 1.1 mg/kg
For compound 4 the middle estimate is 9.1-fold (0.96 log units) above the measured one; the measured number lies below the stated range.
By their numbers in this assay, from the lowest: compounds 4 and 1 (each within the scatter of the next); then compound 3.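

Cyclopropyl in place of pyridin-4-yl on this aromatic carbon, between two ring nitrogen atoms, gives in this assay an 18-fold lower number from compound 3 to compound 4 (1.26 log units; beyond the scatter), the only single change in the series that can be read so far. This position is therefore not indifferent to its group: with the rest of compound 3 kept, exchanging a six-membered aromatic ring with one hetero atom and a hydrogen-bond acceptor for a three-membered non-aromatic ring of carbon only goes with effect at much smaller doses. The data at hand offer nothing that explains the size of this step.

This single pair changes ring size, aromatic character and the ring nitrogen all at once, so it cannot show which of these differences goes with the step, nor whether the step would hold on a different version of the shared core. A phenyl group on the same carbon would keep the aromatic six-membered ring without the ring nitrogen, and a cyclobutyl or isopropyl group would test how far the result depends on the three-membered ring itself.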